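This account rests on a few compounds, and the source may have more. Where it says the series, first, only, none or still open, it means among the compounds named here.

Measured compounds:
Compound 1 `N#Cc1cnc(NCc2cnccc2C(F)(F)F)cc1N[C@H]1CC[C@@H](O)CC1`: 33%
Compound 2 `N#Cc1cnc(NCc2cnccc2C(F)(F)F)cc1N[C@H]1CC[C@H](O)CC1`: 30%
Compound 3 `N#Cc1cnc(NCc2cnccc2C(F)(F)F)cc1NCCC1CCOCC1`: 23%

In an ADME assay on S9 fraction from liver (Homo sapiens) for metabolic stability, with a stated time of 1 h (on this read-out higher numbers stand for a more stable compound and lower numbers for a less stable compound), compound 1 gives 33%, and it stands within the scatter of both other compounds. Compound 4 `CN(C)C(=O)[C@H]1CC[C@@H](Nc2cc(NCc3cnccc3C(F)(F)F)ncc2C#N)CC1` follows from compound 1 by one change: dimethylcarbamoyl in place of hydroxy on a saturated ring carbon. Going by the values given here, no measured step makes this swap. The closest one also removes the hydroxy, with 2-(oxan-4-yl)ethyl in place of 4-hydroxycyclohexyl, and it is a number 10 percentage points lower from compound 1 to compound 3 (within the scatter). Changing only the drawn configuration gave a number 3 percentage points lower from compound 1 to compound 2 (within the scatter). On the strength of these two steps, the expected change in this assay stays within the scatter, at an estimated a number 6 percentage points lower from compound 1 to compound 4 (within the scatter). Compound 4 is expected at 27%. The estimated range runs from 12% to 45%.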

Compound 4, percent of the compound remaining: 48%
Beside the measured number, compound 4's estimate is 21 percentage points below it, and the stated range ends below it.
By their numbers in this assay, from the lowest: compounds 3, 2 and 1 (each within the scatter of the next); then compound 4.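

In this assay, dimethylcarbamoyl in place of hydroxy on a saturated ring carbon gives a number 15 percentage points higher from compound 1 to compound 4 (beyond the scatter) and is the first step among these compounds to lie beyond the scatter. This position can therefore move the read-out, which neither the change in drawn configuration nor the swap to 2-(oxan-4-yl)ethyl had shown. Nothing available here explains why this change has that effect.

The compounds shown leave open whether a primary carboxamide, a carboxylic acid or an amine on this ring carbon would give a similar number. They also leave open whether compound 4 drawn in the other configuration would match it.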